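A few compounds are considered here, and "the series" means these few. Any claim that something is new, unique, unknown or untested is made for them only; others in the source may bear on it.

Measured so far:
compound 1 `O=Cc1ccc(-c2cn3ccnc3c(-c3ccc4ncn(C5CCCCC5)c4c3)n2)cc1` — 17.5%
compound 2 `Cc1cccc(-c2cn3ccnc3c(-c3ccc4ncn(Cc5ccccc5)c4c3)n2)c1` — 42%

In a functional assay on HT-29 cells (Homo sapiens) for inhibition, read by sulforhodamine B assay, with a stated time of 48 h, tested at 10 uM (a lower number here means less inhibition, a higher number more inhibition at the concentration tested (going by the name of the read-out)), compound 2 gives 42%, the higher of the two numbers. In this assay compound 1 gives 17.5%, lower by a gap beyond the usual scatter. Within the data shown here, compound 1 and compound 2 differ in two places, so no single-change step is available between them. Compound 3 `O=Cc1ccc(-c2cn3ccnc3c(-c3ccc4ncn(Cc5ccccc5)c4c3)n2)cc1` keeps the rest of compound 2 and carries the change (4-formylphenyl in place of 3-methylphenyl on an aromatic carbon). Among the measured compounds shown here, the entering group is the one borne by compound 1. For the step of a number 17 percentage points lower from compound 2 to compound 3 (beyond the scatter) a decrease beyond the scatter is expected. Compound 3 is expected to give 25%, within 10% to 42%.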

Compound 3, a percentage reported as inhibition, at one concentration (the size of the read-out at that concentration, not a potency): 17.5%
For compound 3 the middle estimate is 7.5 percentage points above the measured one; measured number inside the range.
By their numbers in this assay, from the lowest: compounds 1 and 3 (each within the scatter of the next); then compound 2.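

In this assay, among these compounds, with benzyl held on the aromatic nitrogen, 4-formylphenyl in place of 3-methylphenyl gives a number 24.5 percentage points lower from compound 2 to compound 3 (beyond the scatter), the first single-change reading at this aromatic carbon. With 4-formylphenyl held, benzyl in place of cyclohexyl gives no change at the digits printed from compound 1 to compound 3 (within the scatter), so this pair shows no effect of that exchange. Nothing at hand bears on the reason for either step.

On these data alone, whether the drop follows the formyl group itself or its ring position stays open, as does the reading for 4-carboxyphenyl or 4-aminophenyl here. As far as these compounds go, whether cyclohexyl and benzyl also read alike alongside 3-methylphenyl is equally open.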